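The source may hold more compounds than are shown below. What is called first, only, known or untested is meant among the compounds shown, and "the series" means these compounds.

Compound 1 `O=C1NC2(CC2c2ccc3cccc(OCc4ccccc4)c3n2)C(=O)N1c1ccc(Cl)cc1`: 300 mg/kg
Compound 2 `Cc1ccc(N2C(=O)NC3(CC3c3ccc4cccc(OCc5ccccc5)c4n3)C2=O)cc1`: 100 mg/kg

Going by the values given here, in a functional assay on the whole organism (strain Kunming) with Mus musculus as the target, in the maximal electroshock model, with a stated time of 0.5 h (a lower number here means that less compound is needed, a higher number that more compound is needed for the effect), compound 2 stands at the lower of the two numbers measured so far, and compound 1 is the only neighbour. Among the compounds with values here, the one measured step, a 3.0-fold lower number from compound 1 to compound 2 (0.48 log units; beyond the scatter), came with methyl in place of chloro on an aromatic carbon. Compound 3 `COc1ccc(N2C(=O)NC3(CC3c3ccc4cccc(OCc5ccccc5)c4n3)C2=O)cc1` differs from compound 2 in a single spot: methoxy in place of methyl on an aromatic carbon. Within the data shown here, no measured step exchanges methyl for methoxy, so the step from compound 1 to compound 2 bears on this change only loosely, as a sign that a small swap at that aromatic carbon can move the number by a modest amount. With nothing more to go on, the step to compound 3 is expected to be no change at the digits printed from compound 2 to compound 3 (within the scatter), that is, nothing beyond the scatter in either direction. Compound 3 is therefore estimated at 100 mg/kg, with a range from 50 mg/kg to 300 mg/kg.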

Compound 3, minimum effective dose: 30 mg/kg
Compound 3: middle estimate off by 3.3-fold (0.52 log units), on the high side, outside the stated range (below it).
By their numbers in this assay, from the lowest: compound 3; then compound 2; then compound 1.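

In this assay, the exchange of 4-methylphenyl for 4-methoxyphenyl gives a 3.3-fold lower number from compound 2 to compound 3 (0.52 log units; beyond the scatter), so this position still responds when methyl gives way to methoxy, a change that the earlier pair did not cover. Going by these compounds alone, with a 10-fold lower number from compound 1 to compound 3 (1.00 log units; beyond the scatter), the three groups at this aromatic carbon now fall in an order from the lowest number: methoxy, then methyl, then chloro, and the span among them is wider than the single step seen before. Nothing measured here accounts for this order. The compounds shown leave open where an amine, a hydroxyl or a longer chain such as ethoxy would fall in this order at the same carbon. They also leave open whether the order would hold if the shared core were changed.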